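Amine-terminal swap on a urea series, compound 3 pending

The source may hold more compounds than are shown below. What is called first, only, known or untested is meant among the compounds shown, and "the series" means these compounds.

Measured so far:
- compound 1 `COc1cc2c(Oc3c(F)cc(NC(=O)NN4C(=O)C(C)SC4c4c(F)cccc4F)cc3F)ccnc2cc1OCCCN1CCCC1` — 830 nM
- compound 2 `COc1cc2c(Oc3c(F)cc(NC(=O)NN4C(=O)CCSC4c4c(F)cccc4F)cc3F)ccnc2cc1OCCCN1CCc2sccc2C1` — > 20000 nM

The two measured compounds share the core of compound 1 and differ at more than one place, so the two values are taken on their own. In a functional assay on A549 cells (Homo sapiens) for antiproliferative activity, read by MTT assay, with a stated time of 72 h (a lower number here means a stronger inhibitor, a higher number a weaker inhibitor), compound 1 gives 830 nM. Compound 2 is reported only as a limit of the assay, > 20000 nM, and so stands at the limit of > 20000 nM in this assay, at which 1 of the 2 values shown sits, with no number of its own.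

Compound 3 `COc1cc2c(Oc3c(F)cc(NC(=O)NN4C(=O)CCSC4c4c(F)cccc4F)cc3F)ccnc2cc1OCCCN1C[C@H]2CCCC[C@H]2C1` is the next compound to be measured. It differs from compound 2 only at the amine end of the chain: a group of 9 heavy atoms (8 carbon, 1 nitrogen; one five-membered non-aromatic ring with 1 hetero atom, one six-membered non-aromatic ring of carbon only) in place of a group of 9 heavy atoms (7 carbon, 1 nitrogen, 1 sulfur; one five-membered aromatic ring with 1 hetero atom, one six-membered non-aromatic ring with 1 hetero atom), on a saturated chain carbon, three bonds along the chain from an oxygen on an aromatic ring. Among the measured compounds shown here, no measured step covers this exchange, so the size of the expected step rests on the structural change alone and on where compound 2 stands.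

Compound 3 is estimated at 8000 nM in this assay, in a range from 2000 nM to 30000 nM. The expected step from compound 2 to compound 3 is an at least 2.5-fold lower number from compound 2 to compound 3 (0.39 log units; beyond the scatter), an improvement beyond the scatter but with a real chance that the assay again reports only a limit.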

Compound 3, half-maximal inhibitory concentration: 3610 nM
Beside the measured number, compound 3's estimate is 2.2-fold (0.35 log units) above it, within the range that was stated.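

In this assay, the amine end of the chain, on a saturated chain carbon three bonds along the chain from an oxygen on an aromatic ring, proves able to move the read-out: the exchange of the sulfur-containing group for the all-carbon-and-nitrogen group gives an at least 5.5-fold lower number from compound 2 to compound 3 (0.74 log units; beyond the scatter), the only one-place comparison among the compounds shown. Going by these compounds, compound 2 is reported only as a limit of the assay, so this step is a bound and its full size stays unknown: the limit of > 20000 nM in this assay, at which 1 of the 3 values shown sits. The exchange alters several things at once, including the five-membered aromatic ring, the sulfur, the hydrogen-bond acceptor count and the 2 defined stereocentres, and this single step cannot assign the gain to any one of them.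

Compound 1 differs from compound 2 and compound 3 at more than one place, so its value cannot show how its amine end ranks against theirs on the same core. Still open, on these data alone, is how a morpholine or a piperidine at the amine end, a longer chain, or the opposite stereochemistry of the entering group would read in this assay.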